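A few compounds are considered here, and "the series" means these few. Any claim that something is new, unique, unknown or untested is made for them only; others in the source may bear on it.

Of the compounds shown here, three of one series have been measured in a functional assay on MDA-MB-231 cells (Homo sapiens) for antiproliferative activity, read by XTT assay, with a stated time of 48 h; on this read-out lower numbers stand for stronger inhibition and higher numbers for weaker inhibition. Compound 1, `CC(=O)OC[C@H]1O[C@@H](n2cc(CN(c3ccc(C)cc3)S(=O)(=O)c3ccccc3)nn2)[C@H](OC(C)=O)[C@@H](OC(C)=O)[C@@H]1OC(C)=O`, gives 180000 nM. Compound 2, `CC(=O)OC[C@H]1O[C@@H](n2cc(CN(c3ccc(Cl)cc3)S(=O)(=O)c3ccccc3)nn2)[C@H](OC(C)=O)[C@@H](OC(C)=O)[C@@H]1OC(C)=O`, gives 135000 nM. Among the compounds with values here, the only one-point change among the measured pairs is a 1.3-fold lower number from compound 1 to compound 2 (0.12 log units; within the scatter). Compound 3, `CS(=O)(=O)N(Cc1cn([C@@H]2O[C@H](CO)[C@@H](O)[C@H](O)[C@H]2O)nn1)c1ccc(C#N)cc1`, gives 185000 nM; its number is within the scatter of both compound 1 and compound 2, so no ordering among the three can be read from these values.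

The next compound, compound 4, is `CS(=O)(=O)N(Cc1cn([C@@H]2O[C@H](CO)[C@@H](O[C@H]3O[C@H](CO)[C@@H](O)[C@H](O)[C@H]3O)[C@H](O)[C@H]2O)nn1)c1ccc(C#N)cc1`. It differs from compound 3 in one place: 3,4,5-trihydroxy-6-(hydroxymethyl)oxan-2-yl in place of hydrogen on an oxygen on a saturated carbon. Within the data shown here, the change sits on the sugar part of the molecule, and no measured pair touches that part; the one measured step concerns a substituent on an aromatic carbon, and it was itself within the scatter. Among the measured compounds shown here, there is therefore nothing in the measured steps that points to a change in either direction, and the attached sugar is the only guide, which cannot be weighed from these data.

On that basis the expected step in this assay is no change at the digits printed from compound 3 to compound 4 (within the scatter), that is, no step beyond the scatter. Compound 4 is estimated at 185000 nM, with a range from 80000 nM to 450000 nM.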

Compound 4, half-maximal inhibitory concentration: 250000 nM
The estimate for compound 4 lay 1.4-fold (0.13 log units) below the measured number, and the stated range covers the measured number.
By their numbers in this assay, from the lowest: compounds 2, 1, 3 and 4 (each within the scatter of the next).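

In this assay, within the data shown here, this is the first measured look at the sugar part of the molecule, and it gives a 1.4-fold higher number from compound 3 to compound 4 (0.13 log units; within the scatter), a step that lies within the scatter. The change is a substantial one: the hydroxy on a saturated ring carbon becomes (3,4,5-trihydroxy-6-(hydroxymethyl)oxan-2-yl)oxy, which brings in 11 heavy atoms and one more six-membered non-aromatic ring, yet these two numbers cannot be told apart, so this position can carry a very large addition without a readable shift in this cell assay. Nothing measured on these compounds accounts for this result, so it stands as an observation without an explanation.

What the compounds shown leave open is whether a smaller or differently built group on this same oxygen, such as a methyl ether, an acetyl group or a short chain ending in an amine or a carboxylic acid, would move the number beyond the scatter. Among these compounds, it also remains open whether the same added ring would behave alike on a compound from the acetyl-bearing part of the series, since the one step at this position was read on a single parent, compound 3.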